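Pyrazolyl in place of triazolyl on the aryl of compound 1

The source may report more compounds than this note shows. Statements on the series, on what has been measured and on what is new or still open speak of the compounds shown alone.

Compound 1 `O=S(=O)(Nc1nccs1)c1ccc2c(c1)OCC[C@H]2c1ccc(C(F)(F)F)cc1-n1ccnn1` sits in the middle of the three solubility numbers gathered so far. In a physicochemical assay for solubility (on this read-out higher numbers stand for higher solubility and lower numbers for lower solubility), compound 1 gives 154000 nM. Compound 3 `O=S(=O)(Nc1ncccn1)c1ccc2c(c1)OCC[C@@H]2c1ccc(C(F)(F)F)cc1-c1ccc(F)nc1` gives 408000 nM in this assay, the highest of the three, and the gap between compound 1 and compound 3 lies beyond the scatter. Compound 2 `Cn1nccc1-c1cc(C(F)(F)F)ccc1[C@H]1CCOc2cc(S(=O)(=O)Nc3cccc(F)n3)ccc21` gives 27000 nM, the lowest number, and here too the gap to compound 1 lies beyond the scatter. Within the data shown here, no pair of these three compounds differs in a single place, so no step between measured compounds can be read off directly.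

Compound 4 `Cn1nccc1-c1cc(C(F)(F)F)ccc1[C@@H]1CCOc2cc(S(=O)(=O)Nc3nccs3)ccc21` is the next compound to be measured. Relative to compound 1 it carries one change: 1-methyl-1H-pyrazol-5-yl in place of 1H-1,2,3-triazol-1-yl on an aromatic carbon. The group that enters is also present in compound 2, which is the least soluble of the three measured; the rest of compound 2 differs from compound 4, so this is only a pointer, not a measured step. On this basis a moderate drop in solubility is expected for compound 4, with the step estimated as a 2.6-fold lower number from compound 1 to compound 4 (0.41 log units; beyond the scatter). Compound 4 is thus estimated at 60000 nM, with a range from 20000 nM to 180000 nM.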

Compound 4, solubility: 65000 nM
Beside the measured number, compound 4's estimate is 1.1-fold (0.03 log units) below it, and the stated range covers the measured number.
By their numbers in this assay, from the lowest: compound 2; then compound 4; then compound 1; then compound 3.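

In this assay, among these compounds, placing 1-methyl-1H-pyrazol-5-yl in place of 1H-1,2,3-triazol-1-yl on the aromatic carbon ortho to a large group and meta to a trifluoromethyl group gives a 2.4-fold lower number from compound 1 to compound 4 (0.37 log units; beyond the scatter) and is the only single-place step so far. The earlier compounds shown here differ from one another in more than one place, so they could not show that this position responds at all; this step shows that exchanging one five-membered aromatic ring for another here moves the read-out beyond the scatter, though only modestly. No measurement at hand speaks to the reason for this step.

Among the compounds shown here, the one step does not separate the contribution of the methyl group from that of the changed ring atoms, so whether the unmethylated 1H-pyrazol-5-yl would give a number nearer compound 1 or compound 4 stays open. For the compounds shown here, also open are the readings an amine or a carboxylic acid would give on this aromatic carbon, and whether the same exchange gives a similar step with a sulfonamide partner other than the one shared by compound 1 and compound 4.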